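The source may report more compounds than this note shows. Statements on the series, on what has been measured and on what is new or still open speak of the compounds shown alone.

Working notes on the series. In a functional assay on CHO cells for positive allosteric modulation of muscarinic acetylcholine receptor M5 (Homo sapiens), read by calcium flux (on this read-out lower numbers stand for smaller maximal responses and higher numbers for larger maximal responses), compound 1 `CCN(Cc1ccccc1)C(=O)C1CCN(S(=O)(=O)c2ccc3occc3c2)CC1` gives 80%. Compound 2 `CCN(C(=O)C1CCN(S(=O)(=O)c2ccc3occc3c2)CC1)[C@H](C)c1ccccc1` carries methyl in place of hydrogen on a saturated chain carbon bound to an amide-type nitrogen and an aromatic carbon and in this assay compound 2 gives 80%; the step is no change at the digits printed from compound 1 to compound 2 (within the scatter). Compound 3 `CCN(Cc1ccccc1C(F)(F)F)C(=O)C1CCN(S(=O)(=O)c2ccc3[nH]ncc3c2)CC1` rests on a different core, and the difference between the two cores is not broken down here. In this assay compound 3 gives 96%, the highest of the three, beyond the scatter from compound 1 and from compound 2.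

Compound 4 `CCCN(Cc1ccccc1C(F)(F)F)C(=O)C1CCN(S(=O)(=O)c2ccc3[nH]ncc3c2)CC1` is not yet measured. It differs from compound 3 by methyl in place of hydrogen on a saturated chain carbon, two bonds along the chain from an amide-type nitrogen. Within the data shown here, this is the same kind of change as the one from compound 1 to compound 2, but the place differs: there the carbon is bound to an amide-type nitrogen and an aromatic carbon, here it is two bonds along the chain from an amide-type nitrogen. The step from compound 3 to compound 4 is expected to be a number 3 percentage points lower from compound 3 to compound 4 (within the scatter), because no change at the digits printed from compound 1 to compound 2 (within the scatter) and the present change is of the same kind. Compound 4 is expected to give 93% in this assay, estimated between 80% and 105%.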

Compound 4, largest response reached (reported as percent of maximum), in percent of the reference or control that the assay uses: 94%
Compound 4: middle estimate off by 1 percentage points, on the low side; measured number inside the range.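

In this assay the new step reads a number 2 percentage points lower from compound 3 to compound 4 (within the scatter). Methyl in place of hydrogen therefore moves the maximal response beyond the scatter on neither core, and the two steps do not differ: the same change on two cores in this assay, no change at the digits printed (within the scatter) from compound 1 to compound 2 and a number 2 percentage points lower (within the scatter) from compound 3 to compound 4, 2 percentage points apart, within the scatter of two such steps

This does not show that one and the same substitution carries over, as the methyl stands on a carbon bound to an amide-type nitrogen and an aromatic carbon in compound 2, but on a saturated chain carbon, two bonds along the chain from an amide-type nitrogen, in compound 4; two pairs also say nothing about a third core.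

Open, going by these compounds, is whether a longer chain such as butyl, or a chain ending in an amine or a carboxylic acid, would hold the maximal response seen with the propyl chain of compound 4. Equally open, on these data alone, is whether methyl at either place would stay within the scatter on a further core.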